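Methoxy in Place of Methyl: What to Expect for Compound 4

The compounds below may be only part of what the source reports. "The series", "measured", "known", "first", "only" and "open" are said of these compounds alone.

Three compounds have been measured in a functional assay on MOLT-4 cells (Homo sapiens) for cytotoxicity, with a stated time of 72 h; a higher number here means a weaker inhibitor, a lower number a stronger inhibitor:
- compound 1 `Cc1ccc(/C=C2\CCC/C(=C\c3ccc([N+](=O)[O-])cc3)C2=O)cc1` gives 8440 nM
- compound 2 `COc1cc(/C=C2\CCC/C(=C\c3cccc([N+](=O)[O-])c3)C2=O)cc(OC)c1OC` gives 44000 nM
- compound 3 `O=C1/C(=C/c2ccc(Cl)cc2)CCC/C1=C\c1ccccc1[N+](=O)[O-]` gives 3860 nM

Among these three numbers compound 1 stands second highest. Compound 3 gives a lower number, and compound 2 a higher one; both of these gaps lie beyond the usual scatter of repeated measurements, so compound 1 sits between them rather than alongside either.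

Compound 4 `COc1ccc(/C=C2\CCC/C(=C\c3ccc([N+](=O)[O-])cc3)C2=O)cc1` differs from compound 1 in a single place: methoxy in place of methyl on an aromatic carbon. The rest of the shared core, including the nitro-bearing ring on the other side, is unchanged.

For the measured compounds named here, no pair of the measured compounds differs by this kind of single change, so there is no measured step that could serve as a guide. Methyl and methoxy are both small groups, and with nothing in the data pointing either way, the expectation is a step of little size, most likely one that stays within the scatter, with no firm direction. On that basis compound 4 is expected to come out close to compound 1 in this assay, with the estimated step of a 1.1-fold lower number from compound 1 to compound 4 (0.05 log units; within the scatter). The estimate for compound 4 is 7500 nM, with a range from 3000 nM to 19000 nM.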

Compound 4, half-maximal inhibitory concentration: 300000 nM
For compound 4 the middle estimate is 40-fold (1.60 log units) below the measured one; measured number above the stated range.
By their numbers in this assay, from the lowest: compound 3; then compound 1; then compound 2; then compound 4.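

In this assay, putting methoxy in place of methyl on this aromatic carbon, para to a large group, gives a 36-fold higher number from compound 1 to compound 4 (1.55 log units; beyond the scatter), so what stands at this position matters a great deal for this series. For the compounds shown here, the two groups differ only by one oxygen atom, yet that change alone takes the number from the middle of the earlier compounds to the highest of the four, something those compounds could not show, as no two of them differed in just one place. Nothing available here accounts for a step of this size, so the result stands as an observation without an explanation.

It remains open whether the step belongs to the oxygen atom itself or to methoxy in particular, since the compounds shown do not tell how a hydroxyl, a dimethylamino group or a longer chain such as ethoxy would behave at the same place. They also leave open whether the same exchange would give a step of similar size in compounds with the nitro group placed elsewhere on its ring.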